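The compounds below may be only part of what the source reports. "The series", "measured", "known", "first", "only" and "open" are said of these compounds alone.

Working notes on the series. Within the data shown here, compound 1 `OC(Cc1ccccc1)CN1CCC(NCCSC(c2ccc(F)cc2)c2ccc(F)cc2)CC1` in an assay on membranes from striatum (strain Sprague-Dawley) for displacement of a labelled ligand from sodium-dependent dopamine transporter (Rattus norvegicus), read by scintillation counting, with a stated time of 120 min (on this read-out higher numbers stand for weaker inhibition and lower numbers for stronger inhibition), gives 31.4 nM, the lowest of the three numbers measured so far. Compound 2 `[O-][S+](CCNC1CCN(CC(O)Cc2ccccc2)CC1)C(c1ccc(F)cc1)c1ccc(F)cc1` and compound 3 `O=C(c1ccccc1)N1CCC(NCC[S+]([O-])C(c2ccc(F)cc2)c2ccc(F)cc2)CC1` sit on a closely related core; compound 2 gives 91.8 nM and compound 3 gives 79.1 nM in this assay, both beyond the scatter away from compound 1.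

Compound 4 `O=C(C1CC1)N1CCC(NCCSC(c2ccc(F)cc2)c2ccc(F)cc2)CC1` is not yet measured. It differs from compound 1 by cyclopropylcarbonyl in place of 2-hydroxy-3-phenylpropyl on an amine nitrogen in a ring. Among the measured compounds shown here, the one measured step that bears on this is the exchange of the same 2-hydroxy-3-phenylpropyl for an acyl group on the related core, benzoyl there: a 1.2-fold lower number from compound 2 to compound 3 (0.06 log units; within the scatter). For the measured compounds named here, that step stayed within the scatter, and no measured step separates benzoyl from cyclopropylcarbonyl, so nothing here points to a shift in either direction.

The step from compound 1 to compound 4 is therefore expected to be small, a 1.1-fold higher number from compound 1 to compound 4 (0.05 log units; within the scatter), with compound 1 and its value of 31.4 nM as the anchor. Compound 4 is estimated at 35 nM in this assay, with a range from 14 nM to 90 nM.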

Compound 4, inhibition constant: 178 nM
The estimate for compound 4 lay 5.1-fold (0.71 log units) below the measured number; measured number outside the range, above it.
By their numbers in this assay, from the lowest: compound 1; then compounds 3, 2 and 4 (each within the scatter of the next, the first and the last beyond it).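

Among these compounds, on the core of compound 1, cyclopropylcarbonyl in place of 2-hydroxy-3-phenylpropyl on an amine nitrogen in a ring is not a neutral change in this assay: the step is a 5.7-fold higher number from compound 1 to compound 4 (0.75 log units; beyond the scatter), whereas the only earlier exchange for an acyl group, on the related core, was a 1.2-fold lower number from compound 2 to compound 3 (0.06 log units; within the scatter). An acyl group at this position therefore does not carry a single outcome across these compounds, and the two steps differ in both the acyl group and the core, so the shown data cannot assign the contrast to either. No measurement given here accounts for the higher number of compound 4.

The compounds shown leave open whether the step follows the loss of the aromatic ring, the hydroxyl or the gain of the carbonyl. Cyclopropylmethyl or 3-phenylpropyl on the same nitrogen of the core of compound 1 would bear on that question.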